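A 3,5-dichlorophenyl swap on compound 1

The source may report more compounds than this note shows. Statements on the series, on what has been measured and on what is new or still open speak of the compounds shown alone.

In a functional assay on U2OS cells (Homo sapiens) for antiproliferative activity, read by MTT assay, with a stated time of 72 h (a lower number here means a stronger inhibitor, a higher number a weaker inhibitor), compound 1 (`O=C(CSc1cccc(O)c1)Nc1ccc2nc(NC(=O)c3ccccc3)sc2c1`) gives > 100000 nM as a limit of the assay and not a number. Compound 2 (`Oc1ccc(Cl)cc1/C=N/c1ccc(-c2nc3ccccc3o2)c(O)c1`), a structure of a different kind, gives a true reading of 21700 nM in this assay and so shows what a measured value looks like here. Compound 3 (`O=C(CSc1cccc(O)c1)Nc1ccc2nc(NC(=O)c3cc(Cl)cc(Cl)c3)sc2c1`) keeps the core of compound 1 but carries 3,5-dichlorophenyl in place of phenyl on a carbonyl carbon. Going by the values given here, no measured pair of compounds shows what this swap does, so any forecast is rough. The expected step is an at least 1.6-fold lower number from compound 1 to compound 3 (0.22 log units; that floor lies within the scatter) toward a stronger inhibitor, a modest one, and the reading could still stop at the limit. Compound 3 is estimated at 60000 nM with an expected range from 20000 nM to 100000 nM in this measurement.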

Compound 3, half-maximal inhibitory concentration: 1530 nM
Compound 3: the middle estimate sits 39-fold (1.59 log units) above what was measured; measured number below the stated range.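

In this assay, placing 3,5-dichlorophenyl in place of phenyl on a carbonyl carbon gives an at least 65-fold lower number from compound 1 to compound 3 (1.81 log units; beyond the scatter). This shows that the group at this place strongly affects the read-out, since the change here alone separates a compound with no measurable value from one with a true reading. The exact size of the step stays unknown, because compound 1 stands at a limit of the assay and not at a number: the limit of > 100000 nM in this assay, at which 1 of the 3 values shown sits.

With only this one swap shown, the two chlorines cannot be told apart, so it remains open whether a single chlorine would give the same gain. From the compounds shown here alone, it is equally open whether a methoxy group, a carboxylic acid or an amine on this ring would keep or lose that gain.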